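Urea substituent series on the shared core: compound 4 outlook

This account rests on a few compounds, and the source may have more. Where it says the series, first, only, none or still open, it means among the compounds named here.

Measured compounds:
compound 1, `O=C(NC1CCN(Cc2ccn(-c3ccc(C(F)(F)F)cc3)c2)CC1)NS(=O)(=O)c1ccc(F)cc1`, 617 nM
compound 2, `O=C(NC1CCN(Cc2ccn(-c3ccc(C(F)(F)F)cc3)c2)CC1)N1CCCC1Cc1cccnc1`, 26 nM
compound 3, `O=C(NC1CCN(Cc2ccn(-c3ccc(C(F)(F)F)cc3)c2)CC1)N1CC[C@@H](O)C1`, 138 nM

In an assay on HEK293 cells for displacement of a labelled ligand from melanin-concentrating hormone receptor 1 (Homo sapiens) (a higher number here means a weaker inhibitor, a lower number a stronger inhibitor), compound 1 gives the highest number of the three. Its nearest neighbour is compound 3, with a 4.5-fold lower number from compound 1 to compound 3 (0.65 log units; beyond the scatter); the widest gap is to compound 2, with a 24-fold lower number from compound 1 to compound 2 (1.38 log units; beyond the scatter). Between the two replacements themselves, a 5.3-fold higher number from compound 2 to compound 3 (0.72 log units; beyond the scatter).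

Compound 4, `O=C(O)CC(NC(=O)NC1CCN(Cc2ccn(-c3ccc(C(F)(F)F)cc3)c2)CC1)c1ccccc1`, has not yet been measured in this assay. Relative to compound 1 its change is 2-carboxy-1-phenylethyl in place of (4-fluorophenyl)sulfonyl on an amide-type nitrogen.

Both measured steps that start from compound 1 exchange the ((4-fluorophenyl)sulfonyl)amino group on the carbonyl carbon for a nitrogen-linked substituent, and both lower the number, one modestly and one largely. Compound 4 makes an exchange at the same position, but the entering 2-carboxy-1-phenylethyl group is acyclic and carries its own hydrogen-bond donor, unlike either measured replacement, so neither step is a close template. On balance a lowering beyond the scatter is expected, nearer the modest step than the large one. The estimate for compound 4 is 200 nM, within 60 nM to 700 nM, which is expected to mean a 3.1-fold lower number from compound 1 to compound 4 (0.49 log units; beyond the scatter).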

Compound 4, half-maximal inhibitory concentration: 412 nM
Estimate against measurement, compound 4: 2.1-fold (0.31 log units) below; measured number inside the range.
By their numbers in this assay, from the lowest: compound 2; then compound 3; then compounds 4 and 1 (each within the scatter of the next).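

In this assay, 2-carboxy-1-phenylethyl in place of (4-fluorophenyl)sulfonyl on the amide-type nitrogen gives a 1.5-fold lower number from compound 1 to compound 4 (0.18 log units; within the scatter), so leaving the sulfonyl group does not by itself lower the number, as the two earlier replacements had suggested. Among the replacements on the carbonyl carbon, the two pyrrolidin-1-yl groups remain separated from (2-carboxy-1-phenylethyl)amino, with a 3.0-fold higher number from compound 3 to compound 4 (0.48 log units; beyond the scatter) and a 16-fold higher number from compound 2 to compound 4 (1.20 log units; beyond the scatter); the ranking of these substituents therefore spans a wide range, and compound 4 goes against any reading of this position as one where every replacement of the sulfonyl group gains over compound 1. No measurement on hand accounts for these differences.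

Going by these compounds, it remains open whether the carboxylic acid or the phenyl ring of the entering group sets the number of compound 4, which a methyl ester, a primary amide or a plain 1-phenylethyl group at the same nitrogen would begin to separate. Also open, on these data alone, is whether a pyridin-3-yl ring on an open chain at this nitrogen would approach compound 2 or whether the pyrrolidine ring is also required.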